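The compounds below may be only part of what the source reports. "The series", "measured", "known", "first", "only" and "open" are said of these compounds alone.

Of the compounds shown here, three have so far been tested in a toxicity assay on the whole organism (strain Icem-CET (SPF Caw)) for cytotoxicity, with Mus musculus as the target; a higher number here means that more compound is needed for the effect, a lower number that less compound is needed. Compound 1 `COc1ccc(/C(C)=C(\C)C(=O)NC2CC2)cc1` gives 300 mg/kg. Compound 2 `C=CCNC(=O)/C(C)=C(\C)c1ccc(Br)cc1` gives 500 mg/kg. Compound 3 `C#CCNC(=O)/C(C)=C(\C)c1ccc(OC)cc1` gives 400 mg/kg. Among the compounds with values here, on these numbers compound 3 stands second highest of the three, and its gaps to both others are within the scatter; the one directly comparable step, a 1.3-fold higher number from compound 1 to compound 3 (0.12 log units; within the scatter), shows how little a change at the amide nitrogen moved the number. Compound 4 `C#CCNC(=O)/C(C)=C(\C)c1ccccc1` has not yet been measured. It differs from compound 3 in one place: hydrogen in place of methoxy on an aromatic carbon. Within the data shown here, no measured step bears on this particular change: the tested compounds differ at the amide nitrogen or carry another group on the ring, not hydrogen. With so narrow a range of numbers, the step of no change at the digits printed from compound 3 to compound 4 (within the scatter) is expected to stay within the scatter. Compound 4 is therefore estimated at 400 mg/kg, with a range from 200 mg/kg to 800 mg/kg.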

Compound 4, dose for half-maximal effect: 400 mg/kg
The estimate for compound 4 equals the measured number at the digits printed; the range from low to high includes it.
By their numbers in this assay, from the lowest: compounds 1, 3, 4 and 2 (each within the scatter of the next).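

Hydrogen in place of methoxy on the aromatic carbon para to a large group gives no change at the digits printed from compound 3 to compound 4 (within the scatter) in this assay. Within the data shown here, this is the first direct look at this ring position, and on this one pair the methoxy can go without the number moving beyond the scatter. No available evidence explains this result. Going by these compounds, whether an amine, a carboxylic acid or a longer chain at this position would behave the same stays open. The bromine of compound 2 also cannot be judged directly, since that compound differs at the amide nitrogen as well.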